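This account rests on a few compounds, and the source may have more. Where it says the series, first, only, none or still open, it means among the compounds named here.

In a functional assay on CCRF-CEM cells (Homo sapiens) for antiproliferative activity, read by fluorescence and resazurin assay, with a stated time of 48 h (on this read-out higher numbers stand for weaker inhibition and lower numbers for stronger inhibition), compound 2 (`O=C(N/N=C/c1cccnc1)c1cc2ccccc2oc1=O`) gives 9900 nM. That value lies within the scatter of compound 1 (`O=C(N/N=C/c1cccnc1)c1cc2ccc(O)cc2oc1=O`), which gives 14100 nM. It lies beyond the scatter of compound 3 (`O=C(N/N=C/c1ccncc1)c1cc2ccccc2oc1=O`), which gives 3110 nM. Compound 4 (`O=C(N/N=C/c1cccnc1)c1cc2cc([N+](=O)[O-])ccc2oc1=O`) has nitro in place of hydrogen on an aromatic carbon. The closest guide is another exchange on an aromatic carbon, hydrogen in place of hydroxy, which gave a 1.4-fold lower number from compound 1 to compound 2 (0.15 log units; within the scatter). Pyridin-4-yl in place of pyridin-3-yl gave a 3.2-fold lower number from compound 2 to compound 3 (0.50 log units; beyond the scatter), but that change lies elsewhere in the molecule. For the measured compounds named here, no measured compound carries nitro, so no step beyond the scatter is expected in this assay, and no direction is firm. The estimated step is a 1.2-fold lower number from compound 2 to compound 4 (0.09 log units; within the scatter). Compound 4 is expected at 8000 nM, with an estimated range of 2500 nM to 25000 nM.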

Compound 4, half-maximal inhibitory concentration: 17100 nM
Estimate against measurement, compound 4: 2.1-fold (0.33 log units) below; measured number inside the range.
By their numbers in this assay, from the lowest: compound 3; then compounds 2, 1 and 4 (each within the scatter of the next).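

In this assay, nitro on this aromatic carbon, meta to a fused ring and para to a fused ring, gives a 1.7-fold higher number from compound 2 to compound 4 (0.24 log units; within the scatter), so a group of this size enters here without a step beyond the scatter. This is a second exchange on the carbon-only aromatic ring of the shared core that stays within the scatter, after a 1.4-fold lower number from compound 1 to compound 2 (0.15 log units; within the scatter). Nothing available explains why this exchange leaves the number within the scatter.

Going by these compounds, whether an amine or a carboxylic acid on this carbon would also stay within the scatter remains open. So does whether nitro would behave the same way on the pyridin-4-yl compound 3.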